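Shifting the Pyridine Nitrogen in a Series at the Limit

A few compounds are considered here, and "the series" means these few. Any claim that something is new, unique, unknown or untested is made for them only; others in the source may bear on it.

Compound 2 `O=C(Oc1ccc2ccccc2c1)c1cn(-c2ccccc2)nc1-c1cccnc1` was tested in a functional assay on MDA-MB-231 cells (Homo sapiens) for cytotoxicity, read by MTT assay, with a stated time of 48 h; a lower number here means a stronger inhibitor, a higher number a weaker inhibitor. In this assay compound 2 gives > 100000 nM, which is a limit of the assay rather than a number. Its neighbours stand no differently. Compound 1 `CC(C)(C)c1ccc(OC(=O)c2cn(-c3ccccc3)nc2-c2cccnc2)cc1`, carrying 4-(tert-butyl)phenyl on the oxygen next to the carbonyl group, gives > 100000 nM in this assay, again a limit. Compound 3 `O=C(c1cn(-c2ccccc2)nc1-c1ccncc1)N1CCC(Cc2ccccc2)CC1`, which already carries pyridin-4-yl, gives > 100000 nM in this assay, also a limit. Among the measured compounds shown here, the only measured step, a step that the two limits leave unreadable from compound 1 to compound 2, cannot be read because the limit of > 100000 nM in this assay, at which 3 of the 3 values shown sit, covers both of its ends.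

Compound 4 `O=C(Oc1ccc2ccccc2c1)c1cn(-c2ccccc2)nc1-c1ccncc1` has not yet been measured. It differs from compound 2 by pyridin-4-yl in place of pyridin-3-yl on an aromatic carbon. For the measured compounds named here, no measured step speaks to this change, and every value so far sits at the same limit, so compound 4 is expected to remain there as well. The step that the limit leaves unreadable from compound 2 to compound 4 is therefore expected to show nothing beyond the usual scatter. For compound 4 the estimate in this assay is 150000 nM, within a range from 40000 nM to 600000 nM.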

Compound 4, half-maximal inhibitory concentration: > 100000 nM
Compound 4: only a limit was reported (the forecaster's own chance of this, stated with the estimate: 85%); the middle value does not contradict the limit.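

Among the compounds shown here, compound 2 and compound 4 both sit at the same limit, so the change from pyridin-3-yl to pyridin-4-yl gives no step that can be read: the limit of > 100000 nM in this assay, at which 4 of the 4 values shown sit. Whether either group, or any other change among these compounds, can give a measurable value in this assay remains open.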